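The source may report more compounds than this note shows. Statements on the series, on what has been measured and on what is new or still open speak of the compounds shown alone.

In a functional assay on SK-BR-3 cells (Homo sapiens) for inhibition, read by MTT assay, with a stated time of 2 days, tested at 100 uM (a lower number here means less inhibition of growth, a higher number more inhibition of growth at the concentration tested), compound 1 (`CNC(=O)c1cc(Oc2ccc3nc(NC(=O)c4ccc(Cl)cc4)sc3c2)ccn1`) gives 83%, the lowest of the three numbers shown, with compound 3 (`CNC(=O)c1cc(Oc2ccc3nc(NC(=O)c4cc(Cl)cc(Cl)c4)sc3c2)ccn1`) at 84.3% and compound 2 (`CNC(=O)c1cc(Oc2ccc3nc(NC(=O)Nc4ccc(C5CCN(C(C)C)CC5)cc4)sc3c2)ccn1`) at 91.6%, both within the scatter of it. Within the data shown here, the only measured step that changes the same part of the molecule, a number 1.3 percentage points higher from compound 1 to compound 3 (within the scatter), stays within the scatter. Compound 4 (`CNC(=O)c1cc(Oc2ccc3nc(NC(=O)Nc4ccc(Br)cc4)sc3c2)ccn1`) differs from compound 1 by (4-bromophenyl)amino in place of 4-chlorophenyl on a carbonyl carbon. Among the measured compounds shown here, no measured pair shows exactly this change; compound 2, which also carries an amino group on that carbonyl carbon, gives a number close to compound 1. Compound 4 is therefore expected to stay within the scatter of compound 1, an estimated step of a number 2 percentage points higher from compound 1 to compound 4 (within the scatter) in this assay. The estimate for compound 4 is 85%, between 70% and 96%.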

Compound 4, percent growth inhibition at one concentration: 69.2%
Estimate against measurement, compound 4: 15.8 percentage points above; measured number outside the range, below it.
By their numbers in this assay, from the lowest: compound 4; then compounds 1, 3 and 2 (each within the scatter of the next).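

In this assay, the place on the carbonyl carbon, quiet when one chlorinated phenyl replaced another, now responds: a number 13.8 percentage points lower from compound 1 to compound 4 (beyond the scatter) and a number 15.1 percentage points lower from compound 3 to compound 4 (beyond the scatter). With the amino group kept there, the aromatic substituent also counts, with a number 22.4 percentage points lower from compound 2 to compound 4 (beyond the scatter). The data offer no explanation for these steps.

The compounds shown leave open how much of the change belongs to the amino group and how much to bromine, which a chloro analogue, (4-chlorophenyl)amino, could separate. Also open, as far as these compounds go, is how a morpholine or a carboxylic acid would read in place of bromo.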